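Phenyl for cyclohexyl in a series at its limit

This account rests on a few compounds, and the source may have more. Where it says the series, first, only, none or still open, it means among the compounds named here.

Measured in a functional assay on HCT-116 cells (Homo sapiens) for antiproliferative activity, read by MTT assay, with a stated time of 72 h; a higher number here means a weaker inhibitor, a lower number a stronger inhibitor:
- compound 1 `O=C1COc2ccc(-c3cnc(Cl)c(NS(=O)(=O)c4ccc(F)cc4)c3)cc2N1C1CCCCC1`: > 40000 nM
- compound 2 `COc1cccc(N2C(=O)COc3ccc(-c4cnc(OC)c(NS(=O)(=O)c5ccc(F)cc5)c4)cc32)c1`: > 40000 nM
- compound 3 `COc1ncc(-c2ccc3c(c2)N(C2CCCCC2)C(=O)CO3)cc1NS(=O)(=O)c1ccc(F)cc1`: > 40000 nM

Compound 1 gives > 40000 nM in this assay, which is a limit of the assay and not a number. Among the measured compounds shown here, nothing measured so far gives a number to rank it against: the limit of > 40000 nM in this assay, at which 3 of the 3 values shown sit.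

Compound 4 `O=C1COc2ccc(-c3cnc(Cl)c(NS(=O)(=O)c4ccc(F)cc4)c3)cc2N1c1ccccc1` keeps the core of compound 1 and differs in one place: phenyl in place of cyclohexyl on an amide-type nitrogen in a ring. It carries phenyl in place of cyclohexyl on an amide-type nitrogen in a ring.

The closest measured change is a step that the two limits leave unreadable from compound 2 to compound 3, with cyclohexyl in place of 3-methoxyphenyl on that nitrogen. The other change that bears on it is a step that the two limits leave unreadable from compound 1 to compound 3, with methoxy in place of chloro on an aromatic carbon. Neither has a readable size, so no measured size can be carried over. Compound 2, which has 3-methoxyphenyl on that nitrogen, gives > 40000 nM, also a limit.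

No step beyond the scatter is therefore expected in this assay, in either direction. The estimated step is a number no higher from compound 1 to compound 4 (the limit leaves the size open). Compound 4 is expected at about 40000 nM, with an estimated range of 15000 nM to 80000 nM.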

Compound 4, half-maximal inhibitory concentration: 39800 nM
Beside the measured number, compound 4's estimate is 1.0-fold (0.00 log units) above it; the range from low to high includes it.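

In this assay, among the compounds shown here, compound 4 gives 39800 nM, the first value that is a number and not a limit. Compound 1 gives > 40000 nM, which is a limit of the assay. Phenyl in place of cyclohexyl on the amide-type nitrogen thus gives a number no higher from compound 1 to compound 4 (the limit leaves the size open); this step cannot be read in size, like the earlier steps, so the position shows only that a phenyl group there can bring a value into the measurable range, and the series as a whole stays at its limit: the limit of > 40000 nM in this assay, at which 3 of the 4 values shown sit.

The compounds shown leave open whether a methyl group or a longer chain on that nitrogen, or an amine or a carboxylic acid on the phenyl ring, would give a number clearly lower than that of compound 4. They also leave open whether the phenyl group would give a number with methoxy in place of chloro on the aromatic carbon, as that pairing is not among the compounds shown.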